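The source may hold more compounds than are shown below. What is called first, only, known or untested is meant among the compounds shown, and "the series" means these compounds.

Of the compounds shown here, two sharing one core have been read so far in a functional assay (Homo sapiens) for inhibition, with a stated time of 72 h; on this read-out lower numbers stand for stronger inhibition and higher numbers for weaker inhibition: compound 1 `CCn1ccc2cc(C(=O)c3cc(OC)c(OC)c(OC)c3)ccc21` gives 40 nM, and compound 2 `COc1cc(C(=O)c2ccc3c(ccn3CO)c2)cc(OC)c1OC` gives 35 nM. Going by the values given here, compound 2 therefore stands within the scatter of compound 1, its only neighbour, and no order can be drawn between them. Compound 3 `COc1cc(C(=O)c2ccc3c(ccn3CC(=O)O)c2)cc(OC)c1OC` keeps the core and alters one group: carboxy in place of hydroxy on a saturated chain carbon bound to an aromatic nitrogen, (carboxy in place of hydroxy on a saturated chain carbon bound to an aromatic nitrogen). Among the compounds with values here, only one measured step bears on this place. It is a 1.1-fold lower number from compound 1 to compound 2 (0.06 log units; within the scatter), hydroxy in place of methyl on the same kind of carbon, and it stayed within the scatter. Within the data shown here, that step covers only a small exchange, and no measured compound carries a carboxy group, so it offers weak guidance here. A step beyond the scatter towards a higher number, meaning weaker inhibition, is tentatively expected in this assay. For compound 3 the expected value is 150 nM, with an estimated range of 35 nM to 700 nM. This estimate means an expected 4.3-fold higher number from compound 2 to compound 3 (0.63 log units; beyond the scatter).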

Compound 3, half-maximal inhibitory concentration: 476 nM
For compound 3 the middle estimate is 3.2-fold (0.50 log units) below the measured one; low and high end bracket the measured number.
By their numbers in this assay, from the lowest: compounds 2 and 1 (each within the scatter of the next); then compound 3.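

In this assay this position proves not to be indifferent to what it carries: carboxy in place of hydroxy gives a 14-fold higher number from compound 2 to compound 3 (1.13 log units; beyond the scatter), and carboxy in place of methyl on the same carbon gives a 12-fold higher number from compound 1 to compound 3 (1.08 log units; beyond the scatter). The earlier pair had shown only that methyl and hydroxy on a saturated chain carbon bound to an aromatic nitrogen could not be told apart, so nothing yet marked this place as one where inhibition could be lost; carboxy is the first group here to weaken it beyond the scatter, and it does so against both neighbours by a large step. What lies behind this loss cannot be said, as no supporting data accompany these numbers.

As far as these compounds go, whether the loss belongs to the carboxy group itself or would follow any group of its size at this place stays open, and a methyl ester, a primary amide or an amine on the same chain would help separate these readings. A longer chain ending in carboxy would show whether the step depends on how far that group stands from the aromatic nitrogen.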